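The compounds below may be only part of what the source reports. "The series", "measured", "known", "first", "only" and "open" are said of these compounds alone.

Compound 1 `Cc1ccc(NCc2cn(-c3ccccc3)nc2-c2ccc(C)cc2)cc1` and compound 2 `Cc1ccc(-c2nn(-c3ccccc3)cc2CNc2ccccc2)cc1` share the same core and were both tested in an ADME assay on MDBK cells (Bos taurus) for cytotoxicity, read by MTT assay, with a stated time of 72 h; a higher number here means that more compound is tolerated, a lower number that less compound is tolerated. In this assay compound 1 gives > 100000 nM, which is a limit of the assay rather than a number. In this assay compound 2 gives > 100000 nM, which is again a limit of the assay and not a number. Within the data shown here, the single measured step, a step that the two limits leave unreadable from compound 1 to compound 2, cannot be sized because both of its ends are limits; the same point is recorded as the limit of > 100000 nM in this assay, at which 2 of the 2 values shown sit. Compound 2 therefore stands at the limit of this assay, with no number of its own to anchor a comparison.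

Compound 3 `Brc1ccc(-c2nn(-c3ccccc3)cc2CNc2ccccc2)cc1` differs from compound 2 by bromo in place of methyl on an aromatic carbon. Among the measured compounds shown here, no measured step bears directly on this change, and the one step that exists between the measured compounds is unreadable, so there is no basis to expect a move beyond the usual scatter in this assay. On that basis compound 3 is expected to give about 100000 nM in this assay, within a range from 30000 nM to 300000 nM. The step this estimate implies, a number no higher from compound 2 to compound 3 (the limit leaves the size open), is expected to be no larger than the scatter.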

Compound 3, half-maximal cytotoxic concentration: > 100000 nM
Compound 3: no number, only a limit; the forecaster's own chance of this, stated with the estimate: 75%; the middle value sits exactly at the limit.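

In this assay compound 3 gives > 100000 nM, which is a limit of the assay and not a number. Compound 2 also stands at a limit, so the step from compound 2 to compound 3 cannot be read. The compounds shown leave open whether any change to them would bring a value within the readable range, as all remain at one point: the limit of > 100000 nM in this assay, at which 3 of the 3 values shown sit.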